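Swapping a Methoxy for a Dimethylamino Group

The source may report more compounds than this note shows. Statements on the series, on what has been measured and on what is new or still open speak of the compounds shown alone.

Compound 1, with the structure `COc1ccc2c(ccn2S(=O)(=O)c2ccccc2)c1`, was measured in an assay on isolated protein for displacement of a labelled ligand from 5-hydroxytryptamine receptor 6 (Homo sapiens), read by scintillation counting, with a stated time of 1 h (a higher number here means a weaker inhibitor, a lower number a stronger inhibitor), and gave 127 nM. That is the lowest of the two numbers recorded so far. Going by the values given here, the only other measured compound, compound 2 with the structure `CN(C)c1cccc2c1ccn2Cc1ccccc1`, gives in this assay 2560 nM, a number that stands far higher than that of compound 1; the two structures differ in more than one place, so no single step between them can be drawn, and their two values simply show that compound 1 is the stronger of the pair.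

Compound 3, with the structure `CN(C)c1ccc2c(ccn2S(=O)(=O)c2ccccc2)c1`, is a single change away from compound 1: dimethylamino in place of methoxy on an aromatic carbon. Among the compounds with values here, no measured pair in this set isolates such a change, so there is no step to lean on.

The expectation is that the step from compound 1 to compound 3 stays within the usual scatter, a 1.4-fold lower number from compound 1 to compound 3 (0.15 log units; within the scatter), with a slight lean toward a lower number. Compound 3 is therefore estimated to give about 90 nM in this assay, with a plausible range from 30 nM to 300 nM.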

Compound 3, inhibition constant: 82 nM
Compound 3: the middle estimate sits 1.1-fold (0.04 log units) above what was measured; the range from low to high includes it.
By their numbers in this assay, from the lowest: compounds 3 and 1 (each within the scatter of the next); then compound 2.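

Read in this assay, the exchange of methoxy for dimethylamino on this aromatic carbon is a 1.5-fold lower number from compound 1 to compound 3 (0.19 log units; within the scatter). Going by these compounds alone, this is the first step in the set that isolates a single place, and it shows that the two groups cannot be told apart at this position on the core of compound 1. The position therefore accepts a nitrogen-linked group in place of an oxygen-linked one with no difference beyond the scatter, though no data shown here bear on why the two groups read alike.

What the compounds shown leave open is how anything other than these two groups would read at this position, such as a primary amine, a chlorine atom or a longer chain like ethoxy, so a single step cannot show how far this tolerance extends. Within the data shown here, also open is whether the same exchange would read alike with a different group elsewhere on the core, as compound 2 differs from the others in more than one place and offers no step to test this.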